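This account rests on a few compounds, and the source may have more. Where it says the series, first, only, none or still open, it means among the compounds named here.

Measured in an in vitro functional assay on SH-SY5Y cells for agonist activity at Neuronal acetylcholine receptor; alpha3/beta4 (Homo sapiens), read by FLIPR and calcium flux; on this read-out lower numbers stand for smaller maximal responses and higher numbers for larger maximal responses:

Compound 1 `Fc1ccc(C2=CC3CNCC(C2)C3)cn1`: 140%
Compound 2 `C1=C(c2cccnc2)C[C@@H]2CNC[C@H]1C2`: 139%
Compound 3 `CN1CC2C=C(c3ccc(F)nc3)CC(C2)C1`: 25%

Compound 3 stands lowest of the three, far beneath both compound 1 and compound 2. Among the measured compounds shown here, the one measured step that reaches it is a number 115 percentage points lower from compound 1 to compound 3 (beyond the scatter), a methyl in place of hydrogen on the amine nitrogen in a ring; that step removes most of the response.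

Compound 4 `COc1ccc(C2=CC3CC(C2)CN(C)C3)cn1` keeps the methylated amine of compound 3 and changes only the group on the aromatic ring: methoxy in place of fluoro on an aromatic carbon

For the measured compounds named here, no measured step shows what such a swap on the aromatic carbon does. The closest hint is indirect: compound 1 with its fluoro and compound 2 without it give values that lie within the scatter of each other, so the group at that carbon seems to matter little while the amine is unmethylated. Carried over to the methylated pair, the expected step of a number 5 percentage points higher from compound 3 to compound 4 (within the scatter) is small and without clear direction. Compound 4 is therefore estimated at 30%, between 10% and 65%.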

Compound 4, largest response reached (reported as percent of maximum), in percent of the reference or control that the assay uses: 61%
Compound 4: the middle estimate sits 31 percentage points below what was measured, within the range that was stated.
By their numbers in this assay, from the lowest: compound 3; then compound 4; then compounds 2 and 1 (each within the scatter of the next).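

In this assay, the group on this aromatic carbon clearly matters once the ring amine carries a methyl: with methoxy in place of fluoro, the result is a number 36 percentage points higher from compound 3 to compound 4 (beyond the scatter). Among the compounds shown here, this could not be seen from the earlier compounds, where the amine has no methyl and compound 1, with fluoro, gives 140% while compound 2, without it, gives 139%, values within the scatter of each other. Nothing available explains why this swap changes the response.

On these data alone, whether methoxy would have a similar effect with the unmethylated amine of compound 1 remains open. A single step also cannot show how the response would change with other groups on this carbon, such as an amine, a hydroxyl or the longer ethoxy.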